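Para-methoxy benzoate ester of a terpenoid phenol

A few compounds are considered here, and "the series" means these few. Any claim that something is new, unique, unknown or untested is made for them only; others in the source may bear on it.

Measured so far:
- compound 1 `Cc1cc2c(C(C)C)ccc(C)c2cc1OC(=O)c1ccc(C(F)(F)F)cc1`: 28.7%
- compound 2 `CC1=CC[C@H](C(C)C)c2cc(C)c(OC(=O)c3ccccc3)cc21`: 37%
- compound 3 `CC1=CC[C@H](C(C)C)c2cc(C)c(OC(=O)c3cccc(C(F)(F)F)c3)cc21`: 18.3%

All three compounds are esters of a terpenoid phenol, tested in a functional assay on SK-LU-1 cells (Homo sapiens) for antiproliferative activity, read by sulforhodamine B assay, with a stated time of 48 h, tested at 50 uM; on this read-out lower numbers stand for less inhibition and higher numbers for more inhibition at the one concentration tested (going by the name of the read-out). Compound 2 carries a plain benzoate and stands highest of the three numbers; the gap to compound 1, which has a different core and a trifluoromethyl group, is within the usual scatter, so no order between compound 2 and compound 1 can be read from these two values. Compound 3 shares the core of compound 2, and the step of a number 18.7 percentage points lower from compound 2 to compound 3 (beyond the scatter) comes from a trifluoromethyl in place of hydrogen on an aromatic carbon.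

Compound 4 `COc1ccc(C(=O)Oc2cc3c(cc2C)[C@@H](C(C)C)CC=C3C)cc1` differs from compound 2 by methoxy in place of hydrogen on an aromatic carbon. Among the compounds with values here, no measured pair shows a methoxy entering an aromatic ring, so the only step that bears on it, a number 18.7 percentage points lower from compound 2 to compound 3 (beyond the scatter), concerns a different group at a different place and is a loose guide at best. It suggests that adding a group to this ring can lower inhibition, but its size need not carry over. A small downward step or none beyond the scatter is therefore expected, written as a number 7 percentage points lower from compound 2 to compound 4 (within the scatter).

Compound 4 is estimated to give 30%, with a range from 15% to 45%.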

Compound 4, a percentage reported as inhibition, at one concentration (the size of the read-out at that concentration, not a potency): 18.6%
Estimate against measurement, compound 4: 11.4 percentage points above; the range from low to high includes it.
By their numbers in this assay, from the lowest: compounds 3 and 4 (each within the scatter of the next); then compounds 1 and 2 (each within the scatter of the next).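

In this assay the change from phenyl to 4-methoxyphenyl gives a number 18.4 percentage points lower from compound 2 to compound 4 (beyond the scatter) on the shared core, so this place on the benzoate ring, para to a large group, does respond to a change of group. Taken with a number 18.7 percentage points lower from compound 2 to compound 3 (beyond the scatter) this gives two groups on the benzoate ring of this core, a trifluoromethyl and a methoxy, and each comes with a lower number, leaving the plain benzoate of compound 2 above both of its substituted relatives among the compounds shown. Nothing measured here tells why the number falls with the methoxy.

The compounds shown leave open whether any group at this place would keep or raise the number, for instance a hydroxyl, an amine, a single fluorine atom or a longer chain such as ethoxy. They also leave open whether the same change would give a step of similar size on the core of compound 1, and these percentages at a single concentration are not potencies.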